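The source may report more compounds than this note shows. Statements on the series, on what has been measured and on what is new or still open speak of the compounds shown alone.

Of the compounds shown here, three built on one shared core have been tested in a functional assay on HepG2 cells (Homo sapiens) for inhibition, read by MTT assay, with a stated time of 72 h; a lower number here means a stronger inhibitor, a higher number a weaker inhibitor. Compound 1 `Cc1ccccc1-c1cc(C(=O)N2CCC3(CC2)CC(=O)c2nn(C(C)(C)C)cc2O3)c2ccccc2n1` carries a 2-methylphenyl group; in this assay compound 1 gives > 10000 nM, which is a limit of the assay rather than a number. Compound 2 `COc1ccc(-c2cc(C(=O)N3CCC4(CC3)CC(=O)c3nn(C(C)(C)C)cc3O4)c3ccccc3n2)cc1OC` has a 3,4-dimethoxyphenyl group on that aromatic carbon and gives 1560 nM in this assay. Compound 3 `Cc1cc(C(=O)N2CCC3(CC2)CC(=O)c2nn(C(C)(C)C)cc2O3)c2ccccc2n1` has a methyl group there and gives 9480 nM. Of the two numbers shown, compound 2 stands lowest, and the swap from aromatic group to methyl gives a 6.1-fold higher number from compound 2 to compound 3 (0.78 log units; beyond the scatter).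

Compound 4 `CC(C)Oc1cc(C(=O)N2CCC3(CC2)CC(=O)c2nn(C(C)(C)C)cc2O3)c2ccccc2n1` has not yet been measured. It differs from compound 2 in one place: isopropoxy in place of 3,4-dimethoxyphenyl on an aromatic carbon. The step that bears most directly on this change is a 6.1-fold higher number from compound 2 to compound 3 (0.78 log units; beyond the scatter), in which the same 3,4-dimethoxyphenyl group was exchanged for a group without a ring. Compound 4 is therefore expected to move in the same direction, by a 4.5-fold higher number from compound 2 to compound 4 (0.65 log units; beyond the scatter). Compound 4 is estimated to give 7000 nM in this assay, within a range from 2500 nM to 20000 nM.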

Compound 4, half-maximal inhibitory concentration: 3150 nM
Compound 4: middle estimate off by 2.2-fold (0.35 log units), on the high side; low and high end bracket the measured number.
By their numbers in this assay, from the lowest: compound 2; then compound 4; then compound 3. At a limit, above all of these: compound 1.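

In this assay, the group at this position does not need a ring to give a measurable gain over methyl (a 3.0-fold lower number from compound 3 to compound 4 (0.48 log units; beyond the scatter)), yet giving up the 3,4-dimethoxyphenyl ring for isopropoxy still costs something (a 2.0-fold higher number from compound 2 to compound 4 (0.31 log units; beyond the scatter)), so compound 2 stays lowest. Measured against the 2-methylphenyl compound, the ring-free isopropoxy group also comes out ahead (an at least 3.1-fold lower number from compound 1 to compound 4 (0.50 log units; beyond the scatter)), and the size of this step is only a floor. Compound 1 stands at a limit and not at a number: the limit of > 10000 nM in this assay, at which 1 of the 4 values shown sits.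

Going by these compounds, what remains open is whether the oxygen of isopropoxy matters or only the size of the group. An amine such as dimethylamino, or a plain propyl chain on the same aromatic carbon, would help separate the two.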